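Dropping the remaining chloro: expected tolerance of compound 4

The source may hold more compounds than are shown below. What is called first, only, known or untested is meant among the compounds shown, and "the series" means these compounds.

Compound 1, `CC(Sc1nnc(-c2ccncc2)s1)C(=O)Nc1ccc(Cl)cc1Cl`, gives > 50000 nM in an ADME assay on BHK-21 cells (Mesocricetus auratus) for cytotoxicity, with a stated time of 3 days (a lower number here means that less compound is tolerated, a higher number that more compound is tolerated), a limit.
Compound 2, `CC(Sc1nnc(-c2ccncc2)s1)C(=O)Nc1ccccc1Cl`, gives > 50000 nM in this assay, a limit.
Compound 3, `O=C(CCSc1nnc(-c2ccncc2)s1)Nc1ccc(Cl)cc1`, gives 8210 nM in this assay.

Compound 2 stands at the top of what this assay can report: its value is a limit, not a number, and of the three values shown it shares this position with compound 1, as the limit of > 50000 nM in this assay, at which 2 of the 3 values shown sit, records. Among the measured compounds shown here, compound 3 is the one compound here that gives a number. For the measured compounds named here, the only single-point step among the measured compounds, a step that the two limits leave unreadable from compound 1 to compound 2, is unreadable because both ends are limits, so it says nothing about how much a chloro is worth in this assay.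

Compound 4, `CC(Sc1nnc(-c2ccncc2)s1)C(=O)Nc1ccccc1`, differs from compound 2 by hydrogen in place of chloro on an aromatic carbon. Going by the values given here, no measured step bears on this change with a readable size. Since compound 2 already sits at the limit, compound 4 is expected to stay there as well, with a step of a number no higher from compound 2 to compound 4 (the limit leaves the size open) that amounts to no readable shift. Compound 4 is therefore estimated at 50000 nM, with a range from 20000 nM to 120000 nM.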

Compound 4, half-maximal cytotoxic concentration: > 50000 nM
Compound 4: no number, only a limit; the forecaster's own chance of this, stated with the estimate: 65%; the middle value sits exactly at the limit.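

In this assay compound 4 gives > 50000 nM, a limit and not a number, so its steps from compound 1 and compound 2 cannot be read: the limit of > 50000 nM in this assay, at which 3 of the 4 values shown sit.

The compounds shown leave open what either chloro is worth in this assay.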